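Lengthening the carboxy-bearing chain of compound 2

The source may hold more compounds than are shown below. What is called first, only, known or untested is meant among the compounds shown, and "the series" means these compounds.

Compound 2, `O=C(O)CCCCC1=CC[C@@H]2[C@@H](/C=C/[C@@H](O)COc3ccccc3)[C@H](O)C[C@@H]2OC1`, carries a 2-carboxyethyl group in place of the carboxy group of compound 1, `O=C(O)CCC1=CC[C@@H]2[C@@H](/C=C/[C@@H](O)COc3ccccc3)[C@H](O)C[C@@H]2OC1`, on a saturated chain carbon two bonds along the chain from a double-bonded ring carbon. In an ADME assay on CHO cells for agonist activity at prostacyclin receptor (Homo sapiens), read by HTRF and cAMP accumulation (on this read-out higher numbers stand for an effect only at larger amounts of compound and lower numbers for an effect already at smaller amounts), compound 1 reaches only the limit of the assay, > 10000 nM. In this assay compound 2 likewise gives only the limit > 10000 nM. The step that the two limits leave unreadable from compound 1 to compound 2 therefore cannot be read, because of the limit of > 10000 nM in this assay, at which 2 of the 2 values shown sit. Compound 2 thus stands at the limit, with nothing in the shown numbers to place it above or below compound 1. Compound 3, `O=C(O)CCCCCC1=CC[C@@H]2[C@@H](/C=C/[C@@H](O)COc3ccccc3)[C@H](O)C[C@@H]2OC1`, extends the same chain once more: carboxymethyl in place of carboxy on a saturated chain carbon, four bonds along the chain from a double-bonded ring carbon. For the measured compounds named here, the only measured step that bears on this change is the one from compound 1 to compound 2, and its size is hidden behind the two limits. No measured value gives a size or a direction for the step in this assay; the two limits leave only the expectation that compound 3 stays at the limit as well. Compound 3 is therefore estimated to give 12000 nM, between 3000 nM and 40000 nM. The expected step is a step that the limit leaves unreadable from compound 2 to compound 3.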

Compound 3, half-maximal effective concentration: > 10000 nM
Compound 3 ended at the assay's limit; the forecaster's own chance of this, stated with the estimate: 75%; the middle value is on the limit's open side.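

In this assay compound 3 gives > 10000 nM, which is only a limit. The steps from compound 1 and from compound 2 to compound 3 therefore cannot be read, because no number lies behind any of the limits: the limit of > 10000 nM in this assay, at which 3 of the 3 values shown sit.

The compounds shown leave open whether any length of this carboxy-bearing chain on the shared core gives a measurable effect.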